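Longer acid chain replaces nitrile on the shared core

The source may report more compounds than this note shows. Statements on the series, on what has been measured and on what is new or still open speak of the compounds shown alone.

Measured compounds:
compound 1 `C=CCc1cc(C(C)=O)c(O)cc1OCCCCCCC#N` gives 97%
compound 2 `CCc1cc(C(C)=O)c(O)cc1OCCCC(C)(C)C#N` gives 85%

Both compounds were tested in an assay on isolated protein for inhibition of leukotriene B4 receptor 1 (Homo sapiens), tested at 10 uM; a higher number here means more inhibition at the concentration tested (going by the name of the read-out), a lower number less inhibition. Compound 2 stands lowest of the two numbers. Its nearest neighbour is compound 1, whose number is higher by a margin beyond the usual scatter of this kind of measurement; no stepwise comparison between the two has been set out, so nothing more than what the two values show should be read into that gap.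

Compound 3 `CCc1cc(C(C)=O)c(O)cc1OCCCCCC(C)(C)C(=O)O` is the unmeasured compound. It differs from compound 2 in one place: 3-carboxy-3-methylbutyl in place of 1-cyano-1-methylethyl on a saturated chain carbon, three bonds along the chain from an oxygen on an aromatic ring. The change carries a carboxylic acid into the chain where compound 2 bears a nitrile.

For the measured compounds named here, since no step between measured compounds is available to guide the expectation, the estimate rests on the value of compound 2 and the nature of the change. In this assay the step from compound 2 to compound 3 is expected to be small and upward, around a number 5 percentage points higher from compound 2 to compound 3 (within the scatter), within the usual scatter. Compound 3 is therefore estimated at 90%, with a range from 70% to 99%.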

Compound 3, a percentage reported as inhibition, at one concentration (the size of the read-out at that concentration, not a potency): 104%
Compound 3: the middle estimate sits 14 percentage points below what was measured; the measured number lies above the stated range.
By their numbers in this assay, from the lowest: compound 2; then compounds 1 and 3 (each within the scatter of the next).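

At the saturated chain carbon three bonds along the chain from an oxygen on an aromatic ring, replacing 1-cyano-1-methylethyl with 3-carboxy-3-methylbutyl gives, in this assay, a number 19 percentage points higher from compound 2 to compound 3 (beyond the scatter), a modest step. The earlier compounds shown here both ended in a nitrile, so they showed nothing about any other chain end; this step shows that a carboxylic acid can stand there, on a group of 8 heavy atoms in place of 5, with no drop in the read-out. The step alters the chain and its end group together, and no measurement at hand explains the rise.

The compounds shown leave open whether the rise goes with the carboxylic acid or with the longer chain, a question that a nitrile on the longer chain or a carboxylic acid on the shorter one would settle. Also open, from the compounds shown here alone, is how an amide or a methyl ester at the chain end would read in this assay, and what potency lies behind these numbers, each taken at a single concentration.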